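Ring stereocentre inversion and cytotoxicity in the series

This account rests on a few compounds, and the source may have more. Where it says the series, first, only, none or still open, it means among the compounds named here.

Compound 1 `CC(C)CNC(=O)[C@H](C)NC(=O)[C@@]1(Cc2ccccc2)CCN1C(=O)OCc1ccccc1` is the reference. In an ADME assay on HELF cells (Homo sapiens) for cytotoxicity, with a stated time of 3 days (a higher number here means that more compound is tolerated, a lower number that less compound is tolerated), compound 1 is reported only as the limit > 100000 nM. Compound 2 `C[C@H](NC(=O)[C@@]1(Cc2ccccc2)CCN1C(=O)OCc1ccccc1)C(=O)NCc1ccccc1` carries phenyl in place of isopropyl on a saturated chain carbon bound to an amide-type nitrogen. In this assay compound 2 likewise gives only the limit >= 20000 nM. The step that the two limits leave unreadable from compound 1 to compound 2 cannot be sized, since the limit of > 100000 nM in this assay, at which 1 of the 2 values shown sits, and the limit of >= 20000 nM in this assay, at which 1 of the 2 values shown sits, both sit at limits. Compound 3 `CC(C)CNC(=O)[C@H](C)NC(=O)[C@]1(Cc2ccccc2)CCN1C(=O)OCc1ccccc1` differs from compound 1 in one respect only: the two compounds have the same atoms and bonds and differ only in configuration as drawn: 1 of 2 stereo elements differ; a stereocentre at a saturated ring carbon is drawn R in compound 1 and S in compound 3. Going by the values given here, no measured step changes configuration alone, so none bears directly on this change, and the single comparison available is the unreadable one above. Compound 3 is therefore expected to remain at or near the limit, with an estimated step of a number no higher from compound 1 to compound 3 (the limit leaves the size open) in this assay, meaning none beyond the scatter. For compound 3 the estimate in this assay is 100000 nM, with a range from 30000 nM to 300000 nM.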

Compound 3, minimum cytotoxic concentration: > 100000 nM
Compound 3: only a limit was reported; the forecaster's own chance of this, stated with the estimate: 80%; the middle value lies on the limit itself.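

In this assay compound 1 and compound 3 both stand at a limit, so no step can be read between them: the limit of > 100000 nM in this assay, at which 2 of the 3 values shown sit.

The compounds shown leave open whether the configuration drawn at the saturated ring carbon matters for cytotoxicity at concentrations beyond that limit.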